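Series notes: the aryl group at the ring-oxygen position

The source may report more compounds than this note shows. Statements on the series, on what has been measured and on what is new or still open speak of the compounds shown alone.

Two compounds of the shared core have numbers in a functional assay on KBVIN cells (Homo sapiens) for antiproliferative activity, read by sulforhodamine B assay, with a stated time of 3 days; a lower number here means that less compound is needed, a higher number that more compound is needed for the effect. Compound 1 `CCC1=C(O)c2c(oc(-c3ccc(SC)cc3)cc2=O)C(CC)(CC)C1=O` gives 1.38 uM in this assay and stands lowest of the two. Compound 2 `CCC1=C(O)c2c(oc(-c3ccccc3C(F)(F)F)cc2=O)C(CC)(CC)C1=O` gives 43.1 uM in this assay; the gap between compound 1 and compound 2 lies beyond the scatter, so compound 1 needs less compound for the effect.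

Compound 3 `CCC1=C(O)c2c(oc(-c3ccc(O)c(O)c3)cc2=O)C(CC)(CC)C1=O` has not yet been measured in this assay. It differs from compound 1 in one place: 3,4-dihydroxyphenyl in place of 4-(methylsulfanyl)phenyl on an aromatic carbon. Within the data shown here, no measured pair shows this particular change, so the size of its step is open. Given that compound 1 gives 1.38 uM and no comparable swap has been run, a modest move toward a higher number is expected, about a 3.6-fold higher number from compound 1 to compound 3 (0.56 log units; beyond the scatter), though a result within the scatter would not surprise. Compound 3 is estimated at 5 uM in this assay, with a range from 1.2 uM to 25 uM.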

Compound 3, concentration for half-maximal effect: 5.41 uM
Estimate against measurement, compound 3: 1.1-fold (0.03 log units) below; the range from low to high includes it.
By their numbers in this assay, from the lowest: compound 1; then compound 3; then compound 2.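

In this assay, this aryl position now has its first readable single-place swap: 3,4-dihydroxyphenyl in place of 4-(methylsulfanyl)phenyl gives a 3.9-fold higher number from compound 1 to compound 3 (0.59 log units; beyond the scatter), a modest step. The position thus accepts a group with 2 hydrogen-bond donors in place of one with none, and compound 3 still gives a clearly lower printed number, 5.41 uM, than compound 2 at 43.1 uM. Nothing available explains the size of this step.

The compounds shown do not separate the two hydroxyl groups of compound 3, so it remains open whether a single hydroxyl group on the phenyl ring would give a number nearer to compound 1 or to compound 3. Going by these compounds, how an amine or a carboxylic acid on that ring would read in this assay also remains open.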